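A few compounds are considered here, and "the series" means these few. Any claim that something is new, unique, unknown or untested is made for them only; others in the source may bear on it.

Compound 3 `CCN(Cc1ccccc1)C(=O)C1CCN(S(=O)(=O)c2cccnc2)CC1` carries a pyridin-3-yl group on the sulfonyl sulfur of the shared core. In a functional assay on CHO cells for positive allosteric modulation of muscarinic acetylcholine receptor M5 (Homo sapiens), read by calcium flux (on this read-out higher numbers stand for an effect only at larger amounts of compound and lower numbers for an effect already at smaller amounts), compound 3 gives > 10000 nM, which is a limit of the assay and not a number. Compound 1 `CCN(Cc1ccccc1)C(=O)C1CCN(S(=O)(=O)c2cccc(OC)c2)CC1` differs from it at the same sulfonyl sulfur; in this assay compound 1 gives 3090 nM; 3100 nM (2 entries), and its two entries agree closely with each other (the several entries of compound 1 in this assay, 3090 nM; 3100 nM (2 entries)). Compound 2 `CCN(Cc1ccccc1)C(=O)C1CCN(S(=O)(=O)c2ccc(OC)c(OC)c2)CC1` is a further variant at that position; in this assay compound 2 gives > 10000 nM; > 10000 nM (2 entries), again a limit of the assay. Compound 3 thus sits at the limit, with two further entries from compound 2 that also report no single number, while compound 1 alone gives a measured value. Compound 4 `CCN(Cc1ccccc1)C(=O)C1CCN(S(=O)(=O)c2ccccn2)CC1` differs from compound 3 by pyridin-2-yl in place of pyridin-3-yl on a sulfonyl sulfur. For the measured compounds named here, no step between two measured compounds is available to set a size for this change. Compound 4 is expected to give about 12000 nM, within a range from 4000 nM to 40000 nM, most probably again reported only as a limit. The expected step that the limit leaves unreadable from compound 3 to compound 4 is therefore none beyond the usual scatter.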

Compound 4, half-maximal effective concentration: > 10000 nM
Compound 4: only a limit was reported; the forecaster's own chance of this, stated with the estimate: 75%; the middle value is on the limit's open side.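

For the compounds shown here, compound 3 and compound 4 are both reported only as limits of the assay, and no step between them can be read. The compounds shown leave open whether pyridin-2-yl and pyridin-3-yl on a sulfonyl sulfur differ at all in this assay.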